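Aryl substituent changes in a small kinase inhibition series

The source may hold more compounds than are shown below. What is called first, only, known or untested is meant among the compounds shown, and "the series" means these compounds.

Measured in an assay on isolated protein for inhibition of ribosomal protein S6 kinase alpha-2 (Homo sapiens), read by fluorescence, with a stated time of 20 min, tested at 10 uM; a lower number here means less inhibition, a higher number more inhibition at the concentration tested (going by the name of the read-out):
compound 1 `O=C1c2ccccc2C(=O)N1CNc1ccc(F)cc1`: 56.7%
compound 2 `Cc1ccc(NCN2C(=O)c3ccccc3C2=O)cc1`: 54%
compound 3 `O=C1c2ccccc2C(=O)N1CNc1ccc(OC(F)(F)F)cc1`: 28.1%

Compound 3 stands lowest of the three measured numbers in this assay; its nearest neighbour is compound 2 and that gap is beyond the scatter, as is the gap to compound 1. The next compound, compound 4 `O=C1c2ccccc2C(=O)N1CNc1ccc(O)cc1`, differs from compound 3 in one place: hydrogen in place of trifluoromethyl on an oxygen on an aromatic ring. The measured steps that alter the same aromatic substituent are a number 28.6 percentage points lower from compound 1 to compound 3 (beyond the scatter) and a number 25.9 percentage points lower from compound 2 to compound 3 (beyond the scatter), whereas a number 2.7 percentage points lower from compound 1 to compound 2 (within the scatter). Going by the values given here, no measured step exchanges trifluoromethoxy for hydroxy, so the direction rests only on the observation that the two smaller groups gave the higher numbers. A return toward that range is expected of compound 4, a number 16.9 percentage points higher from compound 3 to compound 4 (beyond the scatter). The estimate for compound 4 is 45%, between 20% and 70%.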

Compound 4, a percentage reported as inhibition, at one concentration (the size of the read-out at that concentration, not a potency): 101%
Compound 4: the middle estimate sits 56 percentage points below what was measured; measured number above the stated range.
By their numbers in this assay, from the lowest: compound 3; then compounds 2 and 1 (each within the scatter of the next); then compound 4.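

In this assay, going by these compounds alone, hydroxy is the first group on this aromatic carbon to separate from both fluoro and methyl: a number 44.3 percentage points higher from compound 1 to compound 4 (beyond the scatter) and a number 47 percentage points higher from compound 2 to compound 4 (beyond the scatter). Removing trifluoromethyl from the oxygen spans the full measured range of the four compounds, a number 72.9 percentage points higher from compound 3 to compound 4 (beyond the scatter), so this position can move the number far more than the exchange of fluoro for methyl suggested. No evidence on the origin of this difference is available.

Open, as far as these compounds go, is whether a methoxy group or an amine in the same place would read like hydroxy or like trifluoromethoxy. These single-concentration readings also do not give a potency for compound 4.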